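The source may hold more compounds than are shown below. What is called first, only, known or untested is meant among the compounds shown, and "the series" means these compounds.

Measured compounds and their values in a functional assay on NUGC-3 cells (Homo sapiens) for cytotoxicity, read by sulforhodamine B assay, with a stated time of 72 h; on this read-out lower numbers stand for stronger inhibition of growth and higher numbers for weaker inhibition of growth:

Compound 1 `CC(=O)N1c2ccccc2CCC1C(=O)Nc1ccccc1O` gives 49700 nM
Compound 2 `O=C(Nc1ccccc1O)C1CCc2ccccc2N1C(=O)c1ccc(Cl)cc1` gives 13400 nM
Compound 3 `CCCCCCCCC(=O)N1c2ccccc2CCC1C(=O)Nc1ccccc1O` gives 31100 nM

All three share the same core and differ only in the group on the carbonyl carbon attached to the ring nitrogen. Among the three, compound 3 has the second highest number: its nearest neighbour is compound 1 (a 1.6-fold lower number from compound 1 to compound 3 (0.20 log units; within the scatter)), while compound 2 stands further off (a 2.3-fold higher number from compound 2 to compound 3 (0.37 log units; beyond the scatter)).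

Compound 4 `O=C(Nc1ccccc1O)C1CCc2ccccc2N1C(=O)c1cccc(Cl)c1` is the next step from compound 3, and the change is 3-chlorophenyl in place of octyl on a carbonyl carbon. Two measured steps speak to it. The step from compound 2 to compound 3 is the same kind of change run backwards, aryl to chain rather than chain to aryl, and it was a 2.3-fold higher number from compound 2 to compound 3 (0.37 log units; beyond the scatter). The step from compound 1 to compound 2, methyl to 4-chlorophenyl, was a 3.7-fold lower number from compound 1 to compound 2 (0.57 log units; beyond the scatter). Both say that a chlorophenyl group on that carbonyl carbon goes with a lower number than a plain chain. Compound 4 is therefore expected to give a modestly lower number than compound 3, a 2.1-fold lower number from compound 3 to compound 4 (0.32 log units; beyond the scatter), landing close to compound 2. The estimate for compound 4 in this assay is 15000 nM, with a range from 6000 nM to 35000 nM.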

Compound 4, concentration for 50% growth inhibition: 11000 nM
The estimate for compound 4 lay 1.4-fold (0.13 log units) above the measured number; the range from low to high includes it.
By their numbers in this assay, from the lowest: compounds 4 and 2 (each within the scatter of the next); then compounds 3 and 1 (each within the scatter of the next).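

In this assay, 3-chlorophenyl in place of octyl on the carbonyl carbon gives a 2.8-fold lower number from compound 3 to compound 4 (0.45 log units; beyond the scatter), and 3-chlorophenyl in place of methyl gives a 4.5-fold lower number from compound 1 to compound 4 (0.65 log units; beyond the scatter), so the lower number seen with the 4-chlorophenyl group of compound 2 is not unique to that group: both chlorophenyl compounds sit below both chain compounds, and none of the four goes against this. Exchanging 4-chlorophenyl for 3-chlorophenyl gives a 1.2-fold lower number from compound 2 to compound 4 (0.09 log units; within the scatter), so these two placements of the chlorine on the ring cannot be told apart in this assay. Nothing measured here explains why a chlorophenyl group goes with stronger inhibition of growth than these chains do.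

Going by these compounds, it stays open whether the chlorine contributes at all or whether the aromatic ring alone is enough, a question that a plain phenyl group on the same carbonyl carbon would address. On these data alone, how a ring carrying a bromine, an amine or a carboxylic acid in place of the chlorine would compare also remains unknown.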